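Halogen swap on the core: notes on compounds 1 to 4

The source may hold more compounds than are shown below. What is called first, only, known or untested is meant among the compounds shown, and "the series" means these compounds.

Working notes on three measured amides and one open position. Among the compounds with values here, compound 1 `O=C(Nc1ccc(Cl)cc1)c1cc(=O)[nH]c2cc(Br)ccc12` is the first measured member. In a functional assay on KYSE-70 cells for antiproliferative activity against KYSE-70 cell line (Homo sapiens), read by MTT assay, with a stated time of 72 h (on this read-out lower numbers stand for stronger inhibition and higher numbers for weaker inhibition), compound 1 gives only the limit > 20000 nM and no number. Compound 2 `O=C(Nc1ccc(F)cc1)c1cc(=O)[nH]c2cc(Br)ccc12` differs from it in one place. In this assay compound 2 likewise gives only the limit > 20000 nM. The change between them is chloro in place of fluoro on an aromatic carbon, and it produced a step that the two limits leave unreadable from compound 2 to compound 1. Compound 3 `O=C(Nc1cc(F)cc(F)c1)c1cc(=O)[nH]c2cc(F)ccc12` belongs to the same series, but how its core differs from that of compound 2 is not broken down here. In this assay compound 3 also reaches only the limit > 20000 nM. All three values sit at one point, as the limit of > 20000 nM in this assay, at which 3 of the 3 values shown sit, records.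

Compound 4 `O=C(Nc1cc(F)cc(F)c1)c1cc(=O)[nH]c2cc(Cl)ccc12` has not been measured. It differs from compound 3 by chloro in place of fluoro on an aromatic carbon. The place is not the same as in the earlier pair: there the carbon was on a six-membered aromatic ring of carbon only, para to a large group; here it is on a ring that is part of a fused or bridged system of two rings, meta to a fused ring and para to a fused ring. It is therefore the same kind of change, not the same change. No readable step for this change exists among the measured compounds. Because the limit of > 20000 nM in this assay, at which 3 of the 3 values shown sit, holds every value shown, the step from compound 3 to compound 4 is expected to be a step that the limit leaves unreadable from compound 3 to compound 4, with another limit the most likely outcome. Compound 4 is expected to give 30000 nM in this assay, estimated to lie between 10000 nM and 100000 nM.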

Compound 4, half-maximal inhibitory concentration: 9000 nM
Estimate against measurement, compound 4: 3.3-fold (0.52 log units) above, and the stated range ends above it.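

Chloro in place of fluoro, on an aromatic carbon meta to a fused ring and para to a fused ring, gives an at least 2.2-fold lower number from compound 3 to compound 4 (0.34 log units; beyond the scatter) in this assay, and compound 4 is the only one of the four compounds with a number rather than a limit. Going by these compounds, the same kind of change in a different place, in the pair of compound 2 and compound 1, cannot be read because both values are limits: the limit of > 20000 nM in this assay, at which 3 of the 4 values shown sit. This single readable step therefore shows that the swap can matter on the core of compound 3, but it does not show that the gain carries to another core, and its full size stays unknown, as compound 3 has only a limit.

Within the data shown here, it remains open whether chloro at this place would lift a compound off the limit when the amide ring carries the single halogen of compound 1 or compound 2 instead of the two fluoro groups of compound 4. The compounds shown also leave open whether a non-halogen group at the same place, such as an amine, a methoxy group or a carboxylic acid, would keep, extend or lose the activity of compound 4.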